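The source may report more compounds than this note shows. Statements on the series, on what has been measured and on what is new or still open speak of the compounds shown alone.

Measured so far in a functional assay on MCF7 cells (Homo sapiens) for antiproliferative activity, read by MTT assay, with a stated time of 24 h; a higher number here means a weaker inhibitor, a lower number a stronger inhibitor:
Compound 1 `CNC(=O)c1ccccc1Oc1nc(Nc2ccc(C(F)(F)F)cc2)ncc1Br` gives only a limit, > 50000 nM.
Compound 2 `CNC(=O)c1ccccc1Oc1nc(Nc2cccc(Br)c2)ncc1Br` gives 42500 nM.
Compound 3 `CNC(=O)c1ccccc1Oc1nc(Nc2ccccc2OC)ncc1Br` gives only a limit, > 50000 nM.

Compound 3 thus sits at the limit of this assay, a limit shared with one other value (the limit of > 50000 nM in this assay, at which 2 of the 3 values shown sit); no number is known for it. The step to compound 4 `CNC(=O)c1ccccc1Oc1nc(Nc2cccc(OC)c2)ncc1Br` is 3-methoxyphenyl in place of 2-methoxyphenyl on a nitrogen on an aromatic ring. For the measured compounds named here, the one measured step that bears on it, an at least 1.1-fold higher number from compound 2 to compound 3 (0.07 log units; that floor lies within the scatter), is itself only a floor and lies within the scatter, so it fixes no direction. With a 3-bromophenyl on the same nitrogen, compound 2 gives 42500 nM. No step beyond the scatter is therefore expected for compound 4, that is a number no higher from compound 3 to compound 4 (the limit leaves the size open). Compound 4 is estimated at 50000 nM, in the range 20000 nM to 150000 nM, with a fair chance that this assay again reports only a limit.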

Compound 4, half-maximal inhibitory concentration: 18200 nM
Compound 4: the middle estimate sits 2.7-fold (0.44 log units) above what was measured; measured number below the stated range.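

In this assay, for the compounds shown here, the place of the methoxy on the phenyl ring matters: an at least 2.7-fold lower number from compound 3 to compound 4 (0.43 log units; beyond the scatter), the first step beyond the scatter. The size of that step stays open, since compound 3 gives only a limit: the limit of > 50000 nM in this assay, at which 2 of the 4 values shown sit.
At the same place, a 2.3-fold lower number from compound 2 to compound 4 (0.37 log units; beyond the scatter), so methoxy and bromo can also be told apart there.

Open, from the compounds shown here alone, is whether an amine or a carboxylic acid in place of the methoxy of the 3-methoxyphenyl would give a lower number still. Also open, going by these compounds, is whether a longer chain on that oxygen would keep the number of compound 4.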